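From a Bromophenyl Arm to a Dihydroxyphenyl Arm

This account rests on a few compounds, and the source may have more. Where it says the series, first, only, none or still open, it means among the compounds named here.

Compound 1, `COc1cccc(/C=C2\CCC/C(=C\c3cccc(O)c3)C2=O)c1OC` — in a functional assay on A549 cells (Homo sapiens) for cytotoxicity, read by MTT assay, with a stated time of 72 h (on this read-out lower numbers stand for stronger inhibition and higher numbers for weaker inhibition), compound 1 gives a limit, > 20000 nM.
Compound 2, `COc1cccc(/C=C2\CCC/C(=C\c3ccc(O)cc3)C2=O)c1OC` — in this assay compound 2 gives a limit, > 20000 nM.
Compound 3, `COc1ccc(/C=C2\CCC/C(=C\c3ccc(Br)cc3)C2=O)cc1OC` — in this assay compound 3 gives 16000 nM.

For the measured compounds named here, compound 3 holds the only number among the three values shown; the two others are limits. Between compound 1 and compound 2 the only measured step runs a step that the two limits leave unreadable from compound 1 to compound 2, so it cannot be sized. Compound 4, `COc1ccc(/C=C2\CCC/C(=C\c3ccc(O)c(O)c3)C2=O)cc1OC`, is not yet measured. It differs from compound 3 in one place: 3,4-dihydroxyphenyl in place of 4-bromophenyl on a double-bonded chain carbon bound to a double-bonded ring carbon. No measured step bears directly on this change, since none of the shown steps exchanges a bromine-bearing ring for a hydroxyl-bearing one. What can be said is that (the limit of > 20000 nM in this assay, at which 2 of the 3 values shown sit), and both compounds at that limit carry a hydroxyphenyl on the same position. Compound 4 is therefore expected to be no stronger than compound 3 in this assay, with an estimated step of a 1.6-fold higher number from compound 3 to compound 4 (0.19 log units; within the scatter). Compound 4 is estimated at 25000 nM, within a range from 8000 nM to 80000 nM, with a fair chance that only a limit is reported.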

Compound 4, half-maximal inhibitory concentration: > 20000 nM
Compound 4: only a limit was reported; the forecaster's own chance of this, stated with the estimate: 55%; the middle value lies beyond the limit too.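

For the compounds shown here, compound 4 gives the first comparison on one shared core of a bromine-bearing arm and a hydroxyl-bearing arm at this position, on a double-bonded chain carbon bound to a double-bonded ring carbon. Putting 3,4-dihydroxyphenyl in place of 4-bromophenyl gives an at least 1.2-fold higher number from compound 3 to compound 4 (0.09 log units; that floor lies within the scatter), and since compound 4 gives only a limit, this is a floor and not a measured size. The pattern now covers compound 1, compound 2 and compound 4, all hydroxyl-bearing, with compound 3 as the one exception, in this assay: the limit of > 20000 nM in this assay, at which 3 of the 4 values shown sit.

As far as these compounds go, the true size of the step remains open, as does whether the two hydroxyl groups of compound 4 matter singly or together. The compounds shown also leave open how an amine or a carboxylic acid on this phenyl ring would read in this assay.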